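Methyl Added to a Glucose Transporter Inhibitor Scaffold

The source may hold more compounds than are shown below. What is called first, only, known or untested is meant among the compounds shown, and "the series" means these compounds.

Measured so far:
Compound 1 `O=C(CN1C(=O)S/C(=C/c2ccco2)C1=O)Nc1ccc(Cl)c(Cl)c1` gives 152000 nM in an assay on cells for inhibition of solute carrier family 2, facilitated glucose transporter member 4 (Homo sapiens), read by scintillation counting, with a stated time of 10 min; a higher number here means a weaker inhibitor, a lower number a stronger inhibitor.
Compound 2 `O=C(CN1C(=O)S/C(=C/c2ccco2)C1=O)Nc1nc2ccccc2s1` gives 6800 nM in this assay.

Compound 2 shows the lower of these two numbers; compound 1 sits far higher, a gap beyond the usual scatter. Compound 3 `Cc1cccc2sc(NC(=O)CN3C(=O)S/C(=C/c4ccco4)C3=O)nc12` is not yet measured. It differs from compound 2 by methyl in place of hydrogen on an aromatic carbon, a methyl in place of hydrogen on an aromatic carbon. Among the measured compounds shown here, no measured pair shows what such a change does here, so the data give no direction for it. The step expected in this assay is a 1.1-fold lower number from compound 2 to compound 3 (0.05 log units; within the scatter), a change within the scatter. Compound 3 is therefore expected to give about 6000 nM, with a range from 2000 nM to 20000 nM.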

Compound 3, half-maximal inhibitory concentration: 123000 nM
For compound 3 the middle estimate is 21-fold (1.31 log units) below the measured one; the whole stated range lies below it.
By their numbers in this assay, from the lowest: compound 2; then compounds 3 and 1 (each within the scatter of the next).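

Among the compounds shown here, this pair is the first to show what a methyl in place of hydrogen does: on this aromatic carbon, ortho to a fused ring, it gives an 18-fold higher number from compound 2 to compound 3 (1.26 log units; beyond the scatter) in this assay. This position is therefore far from indifferent to a single added carbon. Nothing available explains why the number rises.

From the compounds shown here alone, it remains open whether a methyl on another carbon of this six-membered ring would have a similar effect. It is also unknown whether a fluorine, a hydroxyl or a methoxy group on this same carbon would raise the number as much.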